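Vero cell cytotoxicity notes on a shared-core series

The source may report more compounds than this note shows. Statements on the series, on what has been measured and on what is new or still open speak of the compounds shown alone.

Measured compounds:
- compound 1 `O=C(/C=C/c1ccc(OC(F)(F)F)cc1)Nc1nnc(-c2ccccc2)[nH]1`: in an ADME assay on Vero cells (Chlorocebus sabaeus) for cytotoxicity, read by MTT assay, with a stated time of 72 h (on this read-out higher numbers stand for lower toxicity in this test and lower numbers for higher toxicity in this test), compound 1 gives 1560000 nM
- compound 2 `O=C(/C=C/c1cccc([N+](=O)[O-])c1)Nc1nnc(-c2ccccc2)[nH]1`: in this assay compound 2 gives 1990000 nM
- compound 3 `O=C(/C=C/c1ccc2c(c1)COC2)Nc1nnc(-c2ccccc2)[nH]1`: in this assay compound 3 gives 1820000 nM

Compound 1 holds the lowest of the three numbers in this assay. The nearest to it is compound 3, the furthest compound 2, and both of these gaps fall within the usual scatter of repeated measurements, so the three measured compounds cannot be told apart on this read-out. Among the measured compounds shown here, no pair among them differs in only one place, so no single-point step is available from the measured set.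

The next compound, compound 4 `Cc1ccc(/C=C/C(=O)Nc2nnc(-c3ccccc3)[nH]2)cc1`, is derived from compound 1 by one change: methyl in place of trifluoromethoxy on an aromatic carbon. The three measured values, carrying three different groups at the ring position in question, sit within scatter of one another, which gives no sign that a change at this position moves the number in this assay beyond the scatter in either direction. The step from compound 1 to compound 4 is therefore expected to be a 1.1-fold higher number from compound 1 to compound 4 (0.04 log units; within the scatter), that is, no step beyond the scatter.

For compound 4 the estimated value in this assay is 1700000 nM, with a range from 800000 nM to 3600000 nM.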

Compound 4, half-maximal cytotoxic concentration: 1760000 nM
Estimate against measurement, compound 4: 1.0-fold (0.02 log units) below; the range from low to high includes it.
By their numbers in this assay, from the lowest: compounds 1, 4, 3 and 2 (each within the scatter of the next).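

In this assay the series now has its first step that differs in one place, with methyl in place of trifluoromethoxy on an aromatic carbon, para to a large group (a 1.1-fold higher number from compound 1 to compound 4 (0.05 log units; within the scatter)). The earlier compounds shown here could only suggest by indirect comparison that this part of the molecule tolerates different groups, whereas this pair tests the point directly: a group of 5 heavy atoms with 1 hydrogen-bond acceptor gives way to a group of 1 heavy atom with none, and the two numbers stay within the scatter. This holds for this one pair and this one read-out, and no measurement at hand explains why the two numbers lie so close.

On these data alone, it remains open whether an amine, a carboxylic acid or a longer alkyl chain at this place would give a step beyond the scatter in this assay. All the compounds shown keep the shared core, so they also leave open what a replacement elsewhere in the molecule, such as a methyl on the amide nitrogen, would do to this read-out.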